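The compounds below may be only part of what the source reports. "The series", "measured", "known", "first", "only" and "open" are said of these compounds alone.

Compound 3, `CCCCCCc1cccc(N2CCNCC2)n1`, is the starting point of this step. In a functional assay on the whole organism with Mus musculus as the target, in the maximal electroshock model, with a stated time of 120 min (a lower number here means that less compound is needed, a higher number that more compound is needed for the effect), compound 3 gives 10 mg/kg. Compound 1, `CCCc1cccc(N2CCNCC2)n1`, gives 10 mg/kg in the same test, and compound 2, `CCCCCCCc1cccc(N2CCNCC2)n1`, gives 10 mg/kg, so compound 3 stands level with both of them at the digits shown; the steps of no change at the digits printed from compound 1 to compound 3 (within the scatter) and no change at the digits printed from compound 2 to compound 3 (within the scatter) confirm that nothing beyond the scatter separates the three.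

The next compound is compound 4, `CCCCCCCCCCc1cccc(N2CCNCC2)n1`. The change from compound 3 is butyl in place of hydrogen on a saturated chain carbon, six bonds along the chain from an aromatic carbon. The measured steps that bear on it are all lengthenings of the same chain on the shared core: no change at the digits printed from compound 1 to compound 2 (within the scatter), no change at the digits printed from compound 1 to compound 3 (within the scatter) and no change at the digits printed from compound 2 to compound 3 (within the scatter). Each of them left the minimum effective dose unchanged within the scatter. The step to compound 4 adds another butyl at the far end of that chain, and on the evidence of these three steps no step beyond the scatter is expected in this assay in either direction, so no change at the digits printed from compound 3 to compound 4 (within the scatter) is the expected outcome. Compound 4 is therefore estimated to give 10 mg/kg, with a range from 5 mg/kg to 20 mg/kg.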

Compound 4, minimum effective dose: 30 mg/kg
Beside the measured number, compound 4's estimate is 3.0-fold (0.48 log units) below it, and the stated range ends below it.
By their numbers in this assay, from the lowest: compounds 1, 2 and 3 (each within the scatter of the next); then compound 4.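

Lengthening the chain on the shared core had so far left the minimum effective dose in this assay without a step beyond the scatter, but compound 4 breaks that run, with a 3.0-fold higher number from compound 3 to compound 4 (0.48 log units; beyond the scatter), a 3.0-fold higher number from compound 2 to compound 4 (0.48 log units; beyond the scatter) and a 3.0-fold higher number from compound 1 to compound 4 (0.48 log units; beyond the scatter). An added butyl therefore does not count the same on every chain: the same change on two cores in this assay, no change at the digits printed (within the scatter) from compound 1 to compound 2 and a 3.0-fold higher number (0.48 log units; beyond the scatter) from compound 3 to compound 4, 3.0-fold (0.48 log units) apart, beyond the scatter of two such steps An added propyl shows the same dependence on the chain it extends: the same change on two cores in this assay, no change at the digits printed (within the scatter) from compound 1 to compound 3 and a 3.0-fold higher number (0.48 log units; beyond the scatter) from compound 2 to compound 4, 3.0-fold (0.48 log units) apart, beyond the scatter of two such steps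

The compounds shown leave open at which chain length between those of compound 2 and compound 4 the higher number sets in, and whether a longer chain raises it further. They also leave open whether a hydroxyl group or an amine on the chain would change the picture.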